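Benzyl in place of phenyl in compound 3

The source may report more compounds than this note shows. Statements on the series, on what has been measured and on what is new or still open speak of the compounds shown alone.

Two compounds have numbers in a functional assay on HeLa cells (Homo sapiens) for antiproliferative activity, read by resazurin assay (on this read-out higher numbers stand for weaker inhibition and lower numbers for stronger inhibition), so far

Compound 1 `CCSC(=S)SCC(=O)c1ccc(C)cc1` gives 3980 nM
Compound 2 `Cc1ccc(C(=O)CSC(=S)SCc2ccccc2)cc1` gives 25100 nM

Of the two, compound 2 holds the higher number. Compound 3 `Cc1ccc(C(=O)CSC(=S)SCCc2ccccc2)cc1` is still unmeasured and differs from compound 2 by benzyl in place of phenyl on a saturated chain carbon bound to a sulfur. Going by the values given here, one measured step bears on this place: a 6.3-fold higher number from compound 1 to compound 2 (0.80 log units; beyond the scatter) (modest, beyond the scatter) came with phenyl in place of methyl. Here both groups carry one six-membered aromatic ring of carbon only, so no step beyond the scatter is expected in this assay. The expected change is a 1.3-fold lower number from compound 2 to compound 3 (0.10 log units; within the scatter) and no more than that is estimated. Compound 3 is estimated at 20000 nM with an expected range from 7000 nM to 60000 nM in this measurement.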

Compound 3, half-maximal inhibitory concentration: 39800 nM
Compound 3: the middle estimate sits 2.0-fold (0.30 log units) below what was measured, and the stated range covers the measured number.
By their numbers in this assay, from the lowest: compound 1; then compounds 2 and 3 (each within the scatter of the next).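

In this assay, benzyl in place of phenyl on a saturated chain carbon bound to a sulfur gives a 1.6-fold higher number from compound 2 to compound 3 (0.20 log units; within the scatter) and so does not separate these two compounds. Phenyl in place of hydrogen on a saturated chain carbon, two bonds along the chain from a sulfur, gives a 10-fold higher number from compound 1 to compound 3 (1.00 log units; beyond the scatter) and shows that a second group carrying the aromatic ring also sits on the weaker side, with no compound shown going against this. No measurement shown accounts for these numbers. From the compounds shown here alone, whether a longer chain ending in phenyl would keep the number in this range remains open, as does whether an amine or a carboxylic acid at the end of the chain would bring it back towards that of compound 1.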